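Benzyl for Isopropyl on the Amine of Compound 3

A few compounds are considered here, and "the series" means these few. Any claim that something is new, unique, unknown or untested is made for them only; others in the source may bear on it.

Compound 1, `CC(=O)Oc1ccc(C(=O)Nc2cc3ccc(OCC4CCCN(C)C4)c(C)c3oc2=O)cc1CC=C(C)C`: 740 nM
Compound 2, `CC(=O)Oc1ccc(C(=O)Nc2cc3ccc(OCC4CCCNC4)c(C)c3oc2=O)cc1CC=C(C)C`: 620 nM
Compound 3, `CC(C)=CCc1cc(C(=O)Nc2cc3ccc(OCCCNC(C)C)c(C)c3oc2=O)ccc1O`: 750 nM

Of the compounds shown here, three have been measured in a functional assay on SK-BR-3 cells (Homo sapiens) for antiproliferative activity; on this read-out higher numbers stand for weaker inhibition and lower numbers for stronger inhibition. Their three numbers all lie within the usual scatter of one another, so compound 3 stands level with compound 1 and compound 2 rather than apart from them.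

Compound 4, `CC(C)=CCc1cc(C(=O)Nc2cc3ccc(OCCCNCc4ccccc4)c(C)c3oc2=O)ccc1O`, differs from compound 3 in one place: benzyl in place of isopropyl on an amine nitrogen. Among the measured compounds shown here, the only step between measured compounds is a 1.2-fold lower number from compound 1 to compound 2 (0.08 log units; within the scatter), a change at an amine nitrogen in a ring that left the number essentially where it was. That step bears on the present one only loosely, since it swapped methyl for hydrogen, whereas here benzyl enters for isopropyl at an amine nitrogen whose other neighbour is a saturated chain carbon. No measured pair shows what a benzyl group on such a nitrogen does, so the expectation rests on the one step shown and on the flatness of the three numbers.

The step from compound 3 to compound 4 is therefore expected to be small, a 1.2-fold lower number from compound 3 to compound 4 (0.06 log units; within the scatter), in no clear direction and not beyond the scatter. Compound 4 is estimated at 650 nM in this assay, with a range from 250 nM to 1800 nM.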

Compound 4, half-maximal inhibitory concentration: 470 nM
Compound 4: middle estimate off by 1.4-fold (0.14 log units), on the high side, within the range that was stated.
By their numbers in this assay, from the lowest: compounds 4, 2, 1 and 3 (each within the scatter of the next).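

In this assay, benzyl in place of isopropyl on an amine nitrogen whose other neighbour is a saturated chain carbon gives a 1.6-fold lower number from compound 3 to compound 4 (0.20 log units; within the scatter). Among the compounds shown here, the only earlier step at an amine nitrogen, a 1.2-fold lower number from compound 1 to compound 2 (0.08 log units; within the scatter), concerned a nitrogen in a ring and a change between methyl and hydrogen, whereas this one shows that a group of 7 heavy atoms with a six-membered aromatic ring can replace one of 3 heavy atoms and no ring without the number moving beyond the scatter. Nothing available explains this result or measures any property of either group.

The compounds shown leave open whether this tolerance extends to other groups on the same nitrogen, such as a phenethyl group, a cyclohexylmethyl group or a benzyl ring carrying a methoxy group or a chlorine, and whether the nitrogen can carry a second alkyl group or an acyl group. They also leave open what a longer or shorter chain between the oxygen and this amine would do, and whether a free carboxylic acid at the end of the chain would keep the number within the scatter of these values.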